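Series notes: from compound 2 to compound 3

This account rests on a few compounds, and the source may have more. Where it says the series, first, only, none or still open, it means among the compounds named here.

Of the compounds shown here, two on the shared core have numbers so far in an ADME assay on the whole organism (Rattus norvegicus), at a dose of 2 mg/kg by the oral route; on this read-out lower numbers stand for lower exposure and higher numbers for higher exposure at the dose given (the only read-out at hand). Compound 1 (`COc1cc(OCc2csc(-c3ccc(C(F)(F)F)cc3)n2)c2cc(-c3cn4nc(OC)sc4n3)oc2c1`) gives 726 ng.h/mL and compound 2 (`COc1cc(OCc2cccc(-c3ccc(C(F)(F)F)cn3)c2)c2cc(-c3cn4nc(OC)sc4n3)oc2c1`) gives 459 ng.h/mL on the same scale. These two values lie within the scatter of each other, so compound 2 cannot be separated from compound 1, and two values show no trend.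

Compound 3 (`COc1cc(OCc2cccc(-c3ccc(OC)nc3)c2)c2cc(-c3cn4nc(OC)sc4n3)oc2c1`) keeps the shared core and carries 6-methoxypyridin-3-yl in place of 5-(trifluoromethyl)pyridin-2-yl on an aromatic carbon of a six-membered aromatic ring of carbon only, meta to a large group (6-methoxypyridin-3-yl in place of 5-(trifluoromethyl)pyridin-2-yl on an aromatic carbon).

Going by the values given here, no pair of measured compounds differs in one place only, so nothing yet sizes this change. No step beyond the scatter is therefore expected in this assay in either direction. The expected step, a 1.0-fold higher number from compound 2 to compound 3 (0.02 log units; within the scatter), is small, and the range is kept wide. The estimate rests on compound 2 at 459 ng.h/mL as its anchor. For compound 3 the estimated value is 480 ng.h/mL (range 170 ng.h/mL to 1350 ng.h/mL).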

Compound 3, area under the concentration-time curve: 1800 ng.h/mL
Compound 3: the middle estimate sits 3.8-fold (0.57 log units) below what was measured; the whole stated range lies below it.
By their numbers in this assay, from the lowest: compounds 2 and 1 (each within the scatter of the next); then compound 3.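

In this assay, going by these compounds alone, 6-methoxypyridin-3-yl in place of 5-(trifluoromethyl)pyridin-2-yl, on the aromatic carbon meta to a large group, gives a 3.9-fold higher number from compound 2 to compound 3 (0.59 log units; beyond the scatter) and so provides the first step that can be sized. It shows that oral exposure in this series responds to the group carried at this position, and that a replacement of one substituted pyridine by another is enough to move the number beyond the scatter. Nothing at hand bears on the reason for this step.

The two group names differ both in the substituent on the pyridine and in the ring's point of attachment, so the step cannot yet be divided between those two features. Also open, on these data alone, is whether a different substituent on the same ring, such as an amine, a carboxylic acid or a longer alkoxy chain, would hold, extend or reverse this step, and whether the step would carry over to the side chain of compound 1.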